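The source may hold more compounds than are shown below. What is called first, only, known or untested is meant among the compounds shown, and "the series" means these compounds.

Going by the values given here, in an assay on HEK293 cells for inhibition of Voltage-dependent N-type calcium channel subunit alpha-1B (Homo sapiens), read by FLIPR and calcium flux, in the presence of a further agent that is not named here (on this read-out higher numbers stand for weaker inhibition and lower numbers for stronger inhibition), compound 3 `COc1cccc(OC)c1CN1CCC(N(C2CC2)S(=O)(=O)c2cccc(C(F)(F)F)c2)CC1` gives 60 nM, the lowest of the three numbers so far; compound 1 `O=C(c1ccc(OC(F)(F)F)cc1)N1CCC(N(C2CC2)S(=O)(=O)c2cccc(C(F)(F)F)c2)CC1` gives 300 nM and compound 2 `CS(=O)(=O)c1ccc(F)cc1C(=O)N1CCC(N(C2CC2)S(=O)(=O)c2cccc(C(F)(F)F)c2)CC1` gives 560 nM, both beyond the scatter above compound 3. Compound 4 `CN(C)c1cccc(C(=O)N2CCC(N(C3CC3)S(=O)(=O)c3cccc(C(F)(F)F)c3)CC2)c1` differs from compound 3 by (3-(dimethylamino)phenyl)carbonyl in place of 2,6-dimethoxybenzyl on an amine nitrogen in a ring. Among the compounds with values here, no measured step covers this exchange. Within the data shown here, the one recorded step, a 1.9-fold higher number from compound 1 to compound 2 (0.27 log units; within the scatter), swaps aryl groups on a carbonyl carbon and stays within the scatter, so it bears only indirectly. Compound 4 shares the carbonyl on the ring nitrogen with compound 1, which gives 300 nM, and with compound 2, which gives 560 nM, and these two numbers suggest where it may fall. A rise in this assay is therefore expected for compound 4, estimated as a 5.0-fold higher number from compound 3 to compound 4 (0.70 log units; beyond the scatter). For compound 4 the expected value is 300 nM, within 100 nM to 1000 nM.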

Compound 4, half-maximal inhibitory concentration: 240 nM
Compound 4: the middle estimate sits 1.3-fold (0.10 log units) above what was measured; the measured number falls inside the stated range.
By their numbers in this assay, from the lowest: compound 3; then compounds 4, 1 and 2 (each within the scatter of the next, the first and the last beyond it).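

In this assay the exchange on the amine nitrogen in a ring, (3-(dimethylamino)phenyl)carbonyl in place of 2,6-dimethoxybenzyl, gives a 4.0-fold higher number from compound 3 to compound 4 (0.60 log units; beyond the scatter) and now has a measured size. On the carbonyl carbon, 3-(dimethylamino)phenyl in place of 5-fluoro-2-(methylsulfonyl)phenyl gives a 2.3-fold lower number from compound 2 to compound 4 (0.37 log units; beyond the scatter) while in place of 4-(trifluoromethoxy)phenyl it gives a 1.3-fold lower number from compound 1 to compound 4 (0.10 log units; within the scatter) and so an aryl exchange at this position can pass the scatter, which the earlier step did not. Nothing here gives a cause for these steps. The compounds shown do not separate the carbonyl from the ring substituents in the step from compound 3 to compound 4, and a 3-(dimethylamino)benzyl group on the ring nitrogen would do so.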